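The compounds below may be only part of what the source reports. "The series", "measured", "known", "first", "only" and "open" are said of these compounds alone.

Measured compounds:
compound 1 `COc1ccc(C2=NN(C(=O)C3COc4ccccc4O3)C(c3ccc(F)cc3)C2)cc1`, 6190 nM
compound 2 `COc1ccc(C2=NN(C(=O)C3COc4ccccc4O3)C(c3ccccc3)C2)cc1`, 6310 nM
compound 3 `COc1ccc(C2=NN(C(=O)C3COc4ccccc4O3)C(c3ccc(OC)cc3)C2)cc1`, 11000 nM

In a functional assay on WM 266-4 cells (Homo sapiens) for inhibition, read by MTT assay, with a stated time of 24 h (a lower number here means a stronger inhibitor of growth, a higher number a weaker inhibitor of growth), compound 1 gives the lowest of the three numbers, yet its steps to the others stay within the scatter: a 1.0-fold higher number from compound 1 to compound 2 (0.01 log units; within the scatter) and a 1.8-fold higher number from compound 1 to compound 3 (0.25 log units; within the scatter). The step of a 1.7-fold higher number from compound 2 to compound 3 (0.24 log units; within the scatter) is likewise within the scatter, so the three measured compounds are not distinguishable on this assay.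

Compound 4 `O=C(C1COc2ccccc2O1)N1N=C(c2ccc(Br)cc2)CC1c1ccc(F)cc1` differs from compound 1 by bromo in place of methoxy on an aromatic carbon, which, cut one bond further out, reads 4-methoxyphenyl to 4-bromophenyl. Within the data shown here, none of the measured steps removes this methoxy or introduces a bromo; all three steps concern fluoro, hydrogen and methoxy, and all three lie within the scatter. There is therefore no measured guidance on this particular change, and the only pattern shown is that the shared core tolerates small aromatic substituent swaps without a step beyond the scatter. The expected step of a 1.1-fold lower number from compound 1 to compound 4 (0.05 log units; within the scatter) is accordingly none beyond the scatter, with the range widened for the unmeasured bromo. Compound 4 is estimated at 5500 nM, between 2000 nM and 16000 nM.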

Compound 4, concentration for 50% growth inhibition: 5630 nM
The estimate for compound 4 lay 1.0-fold (0.01 log units) below the measured number; measured number inside the range.
By their numbers in this assay, from the lowest: compounds 4, 1, 2 and 3 (each within the scatter of the next).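

In this assay, among these compounds, bromo in place of methoxy on the aromatic ring that the earlier steps left untouched gives a 1.1-fold lower number from compound 1 to compound 4 (0.04 log units; within the scatter), so this position, para to a large group, takes the swap without a step beyond the scatter. Among the compounds shown here, compound 4 thus shows that, in this series, the methoxy is not needed for growth inhibition at this level, whereas the earlier compounds varied only the other aromatic ring. No independent evidence bears on why the two groups read alike.

From the compounds shown here alone, whether this position would also accept an amine, a carboxylic acid or a longer chain such as butoxy remains open. Also open, going by these compounds, is whether bromo would read the same with hydrogen or methoxy in place of fluoro on the other aromatic ring.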